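The source may report more compounds than this note shows. Statements on the series, on what has been measured and on what is new or still open speak of the compounds shown alone.

Compound 2 `CCn1c(C(=O)N[C@@H](CO)C(C)C)ccc1C(CC)(CC)c1ccc(OCS(=O)(=O)c2ccccc2)c(C)c1` holds the lower of the two numbers in a functional assay on PC-3 cells (Homo sapiens) for antiproliferative activity, read by MTT assay, with a stated time of 24 h (a lower number here means a stronger inhibitor, a higher number a weaker inhibitor), giving 10600 nM, while compound 1 `CCn1c(C(=O)NCCC(=O)OC)ccc1C(CC)(CC)c1ccc(OCS(=O)(=O)c2ccccc2)c(C)c1` gives 40400 nM. Going by the values given here, the one measured step, a 3.8-fold lower number from compound 1 to compound 2 (0.58 log units; beyond the scatter), is the only guide. Compound 3 `CCn1c(C(=O)N[C@@H](C)C(=O)O)ccc1C(CC)(CC)c1ccc(OCS(=O)(=O)c2ccccc2)c(C)c1` differs from compound 2 by 1-carboxyethyl in place of 1-(hydroxymethyl)-2-methylpropyl on an amide-type nitrogen. Among the compounds with values here, that is again an exchange of the group on the amide-type nitrogen, and the sole comparable step was modest, so the expected change a 1.3-fold higher number from compound 2 to compound 3 (0.12 log units; within the scatter) is small, with no direction called beyond the scatter. Compound 3 is estimated at 14000 nM, within 5000 nM to 40000 nM.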

Compound 3, half-maximal inhibitory concentration: 16800 nM
Compound 3: middle estimate off by 1.2-fold (0.08 log units), on the low side, within the range that was stated.
By their numbers in this assay, from the lowest: compounds 2 and 3 (each within the scatter of the next); then compound 1.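

In this assay the exchange on the amide-type nitrogen now has a second outcome: a 1.6-fold higher number from compound 2 to compound 3 (0.20 log units; within the scatter) leaves 1-carboxyethyl and 1-(hydroxymethyl)-2-methylpropyl unseparated. Measured against 2-(methoxycarbonyl)ethyl, 1-carboxyethyl gives a 2.4-fold lower number from compound 1 to compound 3 (0.38 log units; beyond the scatter), so compound 1 stands apart from both compound 2 and compound 3. No available evidence bears on these differences.

Still open, from the compounds shown here alone, is how 1-(methoxycarbonyl)ethyl, the methyl ester of 1-carboxyethyl, would compare on this nitrogen. A benzyl group or an aminoalkyl chain there could also show whether this position tolerates wider change.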